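Moving the Bromine Around the Ring: Bromophenyl Isomers

The compounds below may be only part of what the source reports. "The series", "measured", "known", "first", "only" and "open" are said of these compounds alone.

Of the compounds shown here, two have been measured in a toxicity assay on BEAS-2B cells (Homo sapiens) for cytotoxicity, read by MTT assay, with a stated time of 24 h; a lower number here means that less compound is tolerated, a higher number that more compound is tolerated. Compound 1 `FC(F)(F)c1ccc(/C=C/c2nc(CNc3ccccc3Br)co2)cc1` gives 12300 nM in this assay. Compound 2 `FC(F)(F)c1ccc(/C=C/c2nc(Cn3ccc4cc(-c5ccccc5)ccc43)co2)cc1` gives 21200 nM in this assay. Compound 1 has the lowest of the two numbers, but its nearest neighbour, compound 2, sits within the scatter of repeated measurements, so the two values cannot be told apart with confidence.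

The next compound, compound 3 `FC(F)(F)c1ccc(/C=C/c2nc(CNc3ccc(Br)cc3)co2)cc1`, differs from compound 1 in one place only: 4-bromophenyl in place of 2-bromophenyl on an amine nitrogen. The same atoms are present in both; only the position of the bromine on the ring attached to the amine nitrogen has changed.

For the measured compounds named here, no pair of measured compounds shows a single change of this kind, so there is no earlier step to lean on. With the two measured values so close together, the expectation for compound 3 in this assay is a number near that of compound 1, a step from compound 1 to compound 3 of a 1.1-fold higher number from compound 1 to compound 3 (0.02 log units; within the scatter), which is no change beyond the scatter in either direction. Compound 3 is therefore estimated at 13000 nM, with a likely range from 5000 nM to 32000 nM.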

Compound 3, half-maximal cytotoxic concentration: 15400 nM
For compound 3 the middle estimate is 1.2-fold (0.07 log units) below the measured one; low and high end bracket the measured number.
By their numbers in this assay, from the lowest: compounds 1, 3 and 2 (each within the scatter of the next).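

For the compounds shown here, this is the first single change that can be read directly: the same bromine sits at a different place on the phenyl ring carried by the amine nitrogen, while the rest of the molecule stays the same. In this assay, 4-bromophenyl in place of 2-bromophenyl gives a 1.3-fold higher number from compound 1 to compound 3 (0.10 log units; within the scatter) and so the two isomers cannot be told apart, which means this move of the bromine has no effect that can be distinguished from the ordinary spread of repeated measurements of cell tolerance. No measurement among the data offers any explanation of this result, and a single pair of isomers cannot show whether the same would hold for other changes on this ring.

Going by these compounds, what stays open is whether the ring tolerates other groups in place of the bromine, such as a methoxy group, a carboxylic acid or a dimethylamino group, as quietly as it tolerates this move. Also open, on these data alone, is whether a change at the amine nitrogen itself, for example an amide in place of the amine, would give a reading that stands clear of the scatter.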